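This account rests on a few compounds, and the source may have more. Where it says the series, first, only, none or still open, it means among the compounds named here.

Measured in a functional assay on CAL-51 cells (Homo sapiens) for antiproliferative activity, read by luminescence and CellTiter-Glo, with a stated time of 3 days; a lower number here means a stronger inhibitor, a higher number a weaker inhibitor:
compound 1 `COc1cc(N2CCC(C)(O)CC2)ccc1Nc1nc(O[C@H]2CCOC(C)(C)C2)c2cc[nH]c2n1`: 71 nM
compound 2 `CCOc1cc(C(=O)N(C)C)ccc1Nc1nc(O[C@H]2CC[C@@](C)(O)CC2)c2cc[nH]c2n1`: 26 nM
compound 3 `COc1cc(C(=O)N(C)C)ccc1Nc1nc(OC2CCCC2)c2cc[nH]c2n1`: 497 nM

Compound 1 sits between the other two, with compound 2 lower and compound 3 higher, both gaps lying beyond the scatter. Compound 4 `COc1cc(N2CCN(C3COC3)CC2)ccc1Nc1nc(O[C@H]2CCOC(C)(C)C2)c2cc[nH]c2n1` has 4-(oxetan-3-yl)piperazin-1-yl in place of 4-hydroxy-4-methylpiperidin-1-yl on an aromatic carbon. The rest of compound 1 is kept. Among the measured compounds shown here, no pair of measured compounds differs in one place only, and nothing measured here tests this exchange directly. The expectation therefore stays close to compound 1 at 71 nM, with no step beyond the scatter in this assay in either direction. The estimated step is a 1.2-fold lower number from compound 1 to compound 4 (0.07 log units; within the scatter). For compound 4 the estimated value is 60 nM, with an expected range from 20 nM to 180 nM.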

Compound 4, half-maximal inhibitory concentration: 84 nM
Compound 4: middle estimate off by 1.4-fold (0.15 log units), on the low side, and the stated range covers the measured number.
By their numbers in this assay, from the lowest: compound 2; then compounds 1 and 4 (each within the scatter of the next); then compound 3.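

Across a 1.2-fold higher number from compound 1 to compound 4 (0.07 log units; within the scatter) in this assay, the aromatic carbon para to a large group accepts 4-(oxetan-3-yl)piperazin-1-yl in place of 4-hydroxy-4-methylpiperidin-1-yl, with the step staying within the scatter. In this pair, then, the hydrogen-bond donor of the departing group is not required at this position, and the added second ring is tolerated. No available evidence explains why the two groups read alike. From the compounds shown here alone, whether a carboxylic acid or a simple dimethylamino group would be tolerated on this carbon remains open.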